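The source may report more compounds than this note shows. Statements on the series, on what has been measured and on what is new or still open speak of the compounds shown alone.

In a functional assay on K562 cells (Homo sapiens) for antiproliferative activity, read by MTT assay, with a stated time of 48 h (a higher number here means a weaker inhibitor of growth, a lower number a stronger inhibitor of growth), compound 2 (`COc1ccc(Cn2cnc3c(N(C)c4ccc(OC)cc4)ncnc32)cc1`) gives > 100000 nM, which is a limit of the assay and not a number. Its true value is therefore unknown. Compound 1 (`COc1ccc(N(C)c2nc(Cl)nc3[nH]cnc23)cc1`) gives > 100000 nM, which is also a limit. Together they show (the limit of > 100000 nM in this assay, at which 2 of the 2 values shown sit), so no measured step is available as a guide.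

Compound 3 (`COc1ccc(Cn2cnc3c(N(C)c4ccc(OC)cc4)nc(Cl)nc32)cc1`) differs from compound 2 by one change: chloro in place of hydrogen on an aromatic carbon, between two ring nitrogen atoms (chloro in place of hydrogen on an aromatic carbon). Compound 3 thus holds the chloro also found in compound 1 together with the large group of compound 2, a pairing that neither measured compound has. The chloro alone is no assurance of activity, as compound 1 carries it and still stands at the limit. A moderate shift towards stronger growth inhibition is expected, though no change at all remains quite possible. The expected size of this shift is an at least 5.0-fold lower number from compound 2 to compound 3 (0.69 log units; beyond the scatter), an estimate with wide uncertainty. For compound 3 the estimated value is 20000 nM. The expected range for compound 3 runs from 1000 nM to 100000 nM.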

Compound 3, concentration for 50% growth inhibition: > 100000 nM
Compound 3: only a limit was reported; the forecaster's own chance of this, stated with the estimate: 40%; at least 5.0-fold (0.69 log units) between middle value and limit.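

In this assay compound 3 gives > 100000 nM, which is a limit of the assay and not a number. Neither the step from compound 2 nor the step from compound 1 to compound 3 can therefore be read: the limit of > 100000 nM in this assay, at which 3 of the 3 values shown sit.

The compounds shown leave open whether the chloro or the 4-methoxybenzyl group changes growth inhibition at all.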